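One Methyl Less on Compound 1: Expected Outcome

The source may report more compounds than this note shows. Statements on the series, on what has been measured and on what is new or still open speak of the compounds shown alone.

Compound 1 `C=C1C[C@]23C[C@@]1(O)CC[C@@H]2c1cccc(C)c1[C@@H]3Cn1cc(-c2ccc(C)cc2)nn1` was tested in a functional assay on SW480 cells (Homo sapiens) for cytotoxicity, read by MTT assay, with a stated time of 4 days; a higher number here means a weaker inhibitor, a lower number a stronger inhibitor. There compound 1 gave only a limit, > 20000 nM, not a measured number. Compound 2 `C=C1C[C@]23C[C@@]1(O)CC[C@H]2c1ccc(OS(=O)(=O)c2ccc(C)cc2)c(C)c1[C@@H]3Cn1cc(-c2ccc(OC)cc2)nn1` also gave a limit in this assay, > 20000 nM. Compound 3 `C=C1C[C@]23C[C@@]1(O)CC[C@H]2c1cc(Br)c(O)c(C)c1[C@@H]3Cn1cc(-c2ccccc2)nn1` likewise gave a limit in this assay, > 20000 nM. Every value shown sits at the same point (the limit of > 20000 nM in this assay, at which 3 of the 3 values shown sit), so compound 1 stands there alongside the others and cannot be ranked against them. Compound 4 `C=C1C[C@]23C[C@@]1(O)CC[C@@H]2c1cccc(C)c1[C@@H]3Cn1cc(-c2ccccc2)nn1` differs from compound 1 by hydrogen in place of methyl on an aromatic carbon. Within the data shown here, no measured pair shows what this change does. Because every value shown sits at the limit (the limit of > 20000 nM in this assay, at which 3 of the 3 values shown sit), compound 4 is expected to stay there too, and the step that the limit leaves unreadable from compound 1 to compound 4 is estimated as none beyond the scatter. Compound 4 is therefore estimated at 30000 nM, between 15000 nM and 80000 nM.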

Compound 4, half-maximal inhibitory concentration: > 20000 nM
Compound 4: a limit, no number; the forecaster's own chance of this, stated with the estimate: 80%; the middle value does not contradict the limit.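

Compound 1 and compound 4 both give only a limit, so no step can be read between them: the limit of > 20000 nM in this assay, at which 4 of the 4 values shown sit. How far the compounds shown lie from a measurable effect in this assay stays open.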